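This account rests on a few compounds, and the source may have more. Where it says the series, first, only, none or still open, it means among the compounds named here.

Among the measured compounds shown here, compound 1, `O=[N+]([O-])C1=CNc2nc(-c3ccco3)nn2C1c1ccc(O)cc1O`, is one of two compounds measured in an ADME assay on MDCK cells (Canis lupus familiaris) for cytotoxicity; on this read-out lower numbers stand for higher toxicity in this test and higher numbers for lower toxicity in this test. In this assay, for the measured compounds named here, compound 1 gives 119000 nM, the only number reported among the two values. Compound 2, `O=[N+]([O-])C1=CNc2nc(-c3ccco3)nn2C1c1ccc(O)c(O)c1`, reaches only a limit of this assay at > 1200000 nM. The change between them, an at least 10-fold higher number from compound 1 to compound 2 (1.00 log units; beyond the scatter), concerns the dihydroxyphenyl group on the saturated ring carbon alone.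

Compound 3, `O=[N+]([O-])C1=CNc2ncnn2C1c1ccc(O)cc1O`, has not been measured. It differs from compound 1 by hydrogen in place of furan-2-yl on an aromatic carbon. Going by the values given here, no measured step touches the aromatic carbon between two ring nitrogen atoms, so the only step recorded offers no direct guide to this change. Compound 3 is therefore expected to sit close to compound 1, with a step of a 1.3-fold higher number from compound 1 to compound 3 (0.10 log units; within the scatter) that is expected to stay within the scatter. The estimate for compound 3 in this assay is 150000 nM, within a range from 50000 nM to 600000 nM.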

Compound 3, half-maximal cytotoxic concentration: > 1080000 nM
Compound 3 ended at the assay's limit; the forecaster's own chance of this, stated with the estimate: 20%; middle value at least 7.2-fold (0.85 log units) away from the limit.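

Replacing furan-2-yl with hydrogen on the aromatic carbon between two ring nitrogen atoms gives an at least 9.0-fold higher number from compound 1 to compound 3 (0.95 log units; beyond the scatter), so this position, which the earlier step did not touch, also bears on the read-out in this assay. Compound 1 is now the only one of the three with a number, since changing either the dihydroxyphenyl group or the furan-2-yl leads to a limit. The full size of the new step stays unknown because compound 3 gives a limit of the assay and not a number: the limit of > 1080000 nM in this assay, at which 1 of the 3 values shown sits.

As far as these compounds go, it remains open whether a smaller ring, a methyl or an amine at this position would keep a number like that of compound 1 or also reach a limit. Also open, from the compounds shown here alone, is how hydrogen at this position would combine with the 3,4-dihydroxyphenyl group.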